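The source may report more compounds than this note shows. Statements on the series, on what has been measured and on what is new or still open speak of the compounds shown alone.

In an assay on HEK293 cells for negative allosteric modulation of metabotropic glutamate receptor 5 (Homo sapiens), read by FLIPR, with a stated time of 1 h (on this read-out higher numbers stand for weaker inhibition and lower numbers for stronger inhibition), compound 1 `CC(C)CN1CCc2nc(C#Cc3ccccc3)sc2C1` gives 650 nM. Compound 2 `O=S(=O)(C1CC1)N1CCc2nc(C#Cc3ccccc3)sc2C1` gives 34 nM. Compound 3 `O=C(N1CCCCC1)N1CCc2nc(C#Cc3ccccc3)sc2C1` gives only a limit of the assay, > 10000 nM.

Compound 3 is the weakest of the three: an at least 15-fold higher number from compound 1 to compound 3 (1.18 log units; beyond the scatter) and an at least 290-fold higher number from compound 2 to compound 3 (2.46 log units; beyond the scatter), both reaching the limit (the limit of > 10000 nM in this assay, at which 1 of the 3 values shown sits). Compound 4 `O=C(N1CCCC1)N1CCc2nc(C#Cc3ccccc3)sc2C1` differs from compound 3 by pyrrolidin-1-yl in place of piperidin-1-yl on a carbonyl carbon. Among the compounds with values here, no measured step alters the ring on the carbonyl carbon; the two large steps into compound 3 are the only guide. Compound 4 is expected to stay near the limit, with an estimated step that the limit leaves unreadable from compound 3 to compound 4 in this assay, not beyond the scatter. The estimate for compound 4 is 15000 nM, ranging from 3000 nM to 60000 nM.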

Compound 4, half-maximal inhibitory concentration: > 10000 nM
Compound 4: no number, only a limit; the forecaster's own chance of this, stated with the estimate: 75%; the middle value does not contradict the limit.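

In this assay compound 4 gives only a limit, > 10000 nM. The step between compound 3 and compound 4 cannot be read, but with pyrrolidin-1-yl in place of piperidin-1-yl on the carbonyl carbon, the number stays far from those of the two other compounds, with an at least 290-fold higher number from compound 2 to compound 4 (2.46 log units; beyond the scatter) and an at least 15-fold higher number from compound 1 to compound 4 (1.18 log units; beyond the scatter). Both compounds with a ring on the carbonyl carbon now sit at the same ceiling: the limit of > 10000 nM in this assay, at which 2 of the 4 values shown sit.

Any difference between these two rings remains hidden. Going by these compounds, whether morpholin-4-yl or dimethylamino on the carbonyl carbon would give a readable number stays open.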